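The step from compound 3 to compound 4

The compounds below may be only part of what the source reports. "The series", "measured", "known", "first", "only" and "open" are said of these compounds alone.

Compound 1 `COc1cccc(NC(=O)c2nnn(CC3CCN(C(C)=O)CC3)c2N)c1`: > 50100 nM, a limit
Compound 2 `COc1cccc(NC(=O)c2nnn(Cc3ccc(C#N)cc3)c2N)c1`: > 50100 nM, a limit
Compound 3 `COc1cccc(NC(=O)c2nnn(CC3CCNCC3)c2N)c1`: > 50100 nM, a limit

In a toxicity assay on Vero cells (Chlorocebus sabaeus) for inhibition (on this read-out higher numbers stand for an effect only at larger amounts of compound and lower numbers for an effect already at smaller amounts), compound 3 gives > 50100 nM, which is a limit and not a number. It shares this position with the other measured compounds: the limit of > 50100 nM in this assay, at which 3 of the 3 values shown sit.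

Compound 4 `COc1cccc(NC(=O)c2nnn(Cc3cc(C)on3)c2N)c1` differs from compound 3 as follows: 5-methyl-1,2-oxazol-3-yl in place of piperidin-4-yl on a saturated chain carbon bound to an aromatic nitrogen. The measured change at the same place is a step that the two limits leave unreadable from compound 2 to compound 3, and a step that the two limits leave unreadable from compound 1 to compound 2 is no more informative. Compound 2, with 4-cyanophenyl at that place, is also held at a limit, > 50100 nM.

No change beyond the scatter is therefore expected, and the estimated step that the limit leaves unreadable from compound 3 to compound 4 should be read in that light. For compound 4 the expected value is 60000 nM, within an estimated range of 30000 nM to 120000 nM.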

Compound 4, half-maximal effective concentration: > 50100 nM
Compound 4 gave a limit, no number (the forecaster's own chance of this, stated with the estimate: 85%); the middle value is on the limit's open side.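

In this assay compound 4 gives > 50100 nM, a limit, so its steps from compound 1, compound 2 and compound 3 cannot be read. The compounds shown leave open whether any of these groups changes the read-out, because all the values share one limit: the limit of > 50100 nM in this assay, at which 4 of the 4 values shown sit.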